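The source may hold more compounds than are shown below. What is called first, only, known or untested is meant among the compounds shown, and "the series" means these compounds.

Measured compounds in a physicochemical assay for solubility, read by HPLC, using the shake flask method, measured as kinetic solubility, with a stated time of 2 h, at pH 7.4; on this read-out lower numbers stand for lower solubility and higher numbers for higher solubility:

- compound 1, `Cc1cc(NCc2cccnc2)n2nc(C)c(-c3ccccc3)c2n1`, gives 110000 nM
- compound 2, `Cc1cc(NCCCc2ccccn2)n2nc(C)c(-c3ccccc3)c2n1`, gives 5900 nM
- compound 3, `Cc1cc(NCc2c[nH]cn2)n2nc(C)c(-c3ccccc3)c2n1`, gives 14600 nM

Among these three, compound 3 stands in the middle: its number is lower than that of compound 1, as a 7.5-fold lower number from compound 1 to compound 3 (0.88 log units; beyond the scatter) shows, and higher than that of compound 2, as a 2.5-fold higher number from compound 2 to compound 3 (0.39 log units; beyond the scatter) shows. The next compound, compound 4, `Cc1cc(NCC2CCCCN2)n2nc(C)c(-c3ccccc3)c2n1`, differs from compound 3 in one place: piperidin-2-yl in place of 1H-imidazol-4-yl on a saturated chain carbon bound to a nitrogen on an aromatic ring. Among the compounds with values here, no measured step swaps the same pair of groups, so the evidence is indirect. What the measured steps do show is that exchanging the group on this chain carbon moves solubility by modest to large amounts in both directions, from a 19-fold lower number from compound 1 to compound 2 (1.27 log units; beyond the scatter) to a 2.5-fold higher number from compound 2 to compound 3 (0.39 log units; beyond the scatter). The change from compound 3 to compound 4 is therefore expected to shift this assay by a modest amount, with the direction uncertain and a higher number somewhat more likely, estimated as a 2.1-fold higher number from compound 3 to compound 4 (0.31 log units; beyond the scatter). Compound 4 is accordingly estimated at 30000 nM, within a range from 8000 nM to 120000 nM.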

Compound 4, solubility: 189000 nM
For compound 4 the middle estimate is 6.3-fold (0.80 log units) below the measured one; measured number above the stated range.
By their numbers in this assay, from the lowest: compound 2; then compound 3; then compounds 1 and 4 (each within the scatter of the next).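

In this assay the non-aromatic piperidin-2-yl ring shows that this position can raise the number by a large amount, with a 13-fold higher number from compound 3 to compound 4 (1.11 log units; beyond the scatter) and with a 32-fold higher number from compound 2 to compound 4 (1.51 log units; beyond the scatter) as well. Until now the only rise at this chain carbon was modest. Having an aromatic ring here does not by itself keep the number low, since a 1.7-fold higher number from compound 1 to compound 4 (0.24 log units; within the scatter) leaves compound 1 and compound 4 indistinguishable even though compound 1 carries the aromatic pyridin-3-yl.

Nothing measured here accounts for these shifts. Still open, going by these compounds, is what a cyclohexyl ring, with carbon in place of the piperidine nitrogen, or an open-chain amine on this chain carbon would do, and so whether the ring, its nitrogen or both go with the high number.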